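Propargylamine series: from compound 2 toward compound 3

The source may report more compounds than this note shows. Statements on the series, on what has been measured and on what is new or still open speak of the compounds shown alone.

Compound 2 `C#CCN(CC#C)Cc1cn(-c2cc(NC(=S)NCC)ncn2)cn1` stands at the assay limit in an assay on isolated protein for inhibition of Amine oxidase [flavin-containing] A (Homo sapiens), read by fluorescence and Amplex Red, with a stated time of 15 min; a higher number here means a weaker inhibitor, a lower number a stronger inhibitor: compound 2 gives > 50000 nM, a limit rather than a number. Compound 1 `C#CCN(CCCC)Cc1cn(-c2cc(NC(=S)NCC)ncn2)cn1` likewise gives > 50000 nM in this assay, again a limit. Among the compounds with values here, the one measured step, a step that the two limits leave unreadable from compound 1 to compound 2, is unreadable, and the only point of evidence is the limit of > 50000 nM in this assay, at which 2 of the 2 values shown sit. Compound 3 `C#CCNCCCc1cn(-c2cc(NC(=S)NCC)ncn2)cn1` differs from compound 2 by 2-(propargylamino)ethyl in place of dipropargylamino on a saturated chain carbon bound to an aromatic carbon. Within the data shown here, no measured step bears on this change; the two values shown both sit at the limit and give no direction or size. The half-maximal inhibitory concentration of compound 3 is expected to remain near the limit, and the step of a number no higher from compound 2 to compound 3 (the limit leaves the size open) is estimated as no readable change. For compound 3 the expected value is 50000 nM, within 5000 nM to 200000 nM, with a limit again the likeliest outcome.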

Compound 3, half-maximal inhibitory concentration: > 50000 nM
Compound 3 ended at the assay's limit (the forecaster's own chance of this, stated with the estimate: 70%); the middle value lies on the limit itself.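

No step among compound 1, compound 2 and compound 3 can be read in this assay, where all three stand at a limit of the assay: the limit of > 50000 nM in this assay, at which 3 of the 3 values shown sit.

The compounds shown leave open whether any change to the amine-bearing chain on the shared core gives a readable half-maximal inhibitory concentration in this assay.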